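This account rests on a few compounds, and the source may have more. Where it says the series, first, only, none or still open, it means among the compounds named here.

Compound 1, `Brc1cn2ccnc2c(-c2ccc3ncn(C4CCCCC4)c3c2)n1`, carries a bromo on an aromatic carbon of its shared core. In a functional assay on MDA-MB-231 cells (Homo sapiens) for inhibition, read by sulforhodamine B assay, with a stated time of 48 h, tested at 10 uM (on this read-out higher numbers stand for more inhibition at the one concentration tested (going by the name of the read-out) and lower numbers for less inhibition), compound 1 gives 24.2%, the highest of the three numbers measured here, though the steps to the other two lie within the scatter. Compound 2, `Fc1ccc(-c2cn3ccnc3c(-c3ccc4ncn(C5CCCCC5)c4c3)n2)cc1`, gives 15.8% in this assay, and compound 3, `Brc1ccc(-c2cn3ccnc3c(-c3ccc4ncn(C5CCCCC5)c4c3)n2)cc1`, gives 22.8%.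

The step to compound 4, `c1csc(-c2cn3ccnc3c(-c3ccc4ncn(C5CCCCC5)c4c3)n2)c1`, is thiophen-2-yl in place of bromo on an aromatic carbon. Among the measured compounds shown here, two measured steps bear on it, since each puts a ring in place of the same bromo: a number 8.4 percentage points lower from compound 1 to compound 2 (within the scatter) and a number 1.4 percentage points lower from compound 1 to compound 3 (within the scatter). Neither moved the number beyond the scatter, and the two aryl compounds sit close to each other, as a number 7 percentage points higher from compound 2 to compound 3 (within the scatter) shows.

On that basis a thiophen-2-yl at this place is expected to behave like the other two rings, with a step of a number 4.2 percentage points lower from compound 1 to compound 4 (within the scatter) from compound 1, that is, no change beyond the scatter. Compound 4 is therefore estimated at 20% in this assay, within a range from 9% to 32%.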

Compound 4, a percentage reported as inhibition, at one concentration (the size of the read-out at that concentration, not a potency): 10.8%
Compound 4: middle estimate off by 9.2 percentage points, on the high side; the measured number falls inside the stated range.
By their numbers in this assay, from the lowest: compounds 4, 2, 3 and 1 (each within the scatter of the next, the first and the last beyond it).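

Thiophen-2-yl is the first group at this place, on an aromatic carbon next to the ring nitrogen, to move the number beyond the scatter: in this assay there is a number 13.4 percentage points lower from compound 1 to compound 4 (beyond the scatter) for this change from bromo. The same holds against an aryl group, with a number 12 percentage points lower from compound 3 to compound 4 (beyond the scatter) when thiophen-2-yl takes the place of 4-bromophenyl, so putting a ring at this place does not always leave the number where it was. The separation is only partial, however, since the step against 4-fluorophenyl, a number 5 percentage points lower from compound 2 to compound 4 (within the scatter), stays small enough that compound 4 cannot be told apart from compound 2, and nothing shown here accounts for the change.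

What the compounds shown leave open is how an amine, a carboxylic acid or a longer alkyl chain would read at this place, since every group here is either bromo or an aromatic ring. They also leave open whether an unsubstituted phenyl would fall with compound 4 or with compound 3 in this assay, and how these single-concentration numbers relate to potency.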